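Swapping a Dimethylamino for a Hydroxy Group Across Two Cores

This account rests on a few compounds, and the source may have more. Where it says the series, first, only, none or still open, it means among the compounds named here.

Compound 1 `COc1ccc(C(=O)c2ccc(OC)c3c2C=CC(C)(C)O3)c(NC(=O)CO)c1` and compound 2 `COc1ccc(C(=O)c2ccc(OC)c3c2C=CC(C)(C)O3)c(NC(=O)CN(C)C)c1` share one core and differ in a single place: hydroxy in place of dimethylamino on a saturated chain carbon bound to a carbonyl carbon. In a functional assay on HeLa cells (Homo sapiens) for antiproliferative activity, read by MTT assay, with a stated time of 48 h (a lower number here means a stronger inhibitor, a higher number a weaker inhibitor), compound 2 gives 3620 nM, while compound 1 gives 310 nM, a step of a 12-fold lower number from compound 2 to compound 1 (1.07 log units; beyond the scatter). Compound 3 `C=C(c1cc(OC)c(OC)c(OC)c1)c1ccc(OC)c(O)c1NC(=O)CN(C)C` stands on another core; the difference between the two cores is not broken down here. In this assay compound 3 gives 120 nM, the lowest of the three numbers. Compound 4 `C=C(c1cc(OC)c(OC)c(OC)c1)c1ccc(OC)c(O)c1NC(=O)CO` arises from compound 3 by the same change at the same place: hydroxy in place of dimethylamino on a saturated chain carbon bound to a carbonyl carbon. The expected step is a 6.0-fold lower number from compound 3 to compound 4 (0.78 log units; beyond the scatter), which rests on a 12-fold lower number from compound 2 to compound 1 (1.07 log units; beyond the scatter), tempered somewhat since the core of compound 3 is a different one and the change has been seen only once. Compound 4 is therefore estimated at 20 nM, with a likely range from 6 nM to 70 nM.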

Compound 4, half-maximal inhibitory concentration: 20 nM
The estimate for compound 4 equals the measured number at the digits printed; measured number inside the range.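

In this assay, hydroxy in place of dimethylamino gives a 6.0-fold lower number from compound 3 to compound 4 (0.78 log units; beyond the scatter) on the second core. The change therefore carries over to this core in the same direction, and the two steps do not differ in size beyond what repeated measurements would be expected to show: the same change on two cores in this assay, a 12-fold lower number (1.07 log units; beyond the scatter) from compound 2 to compound 1 and a 6.0-fold lower number (0.78 log units; beyond the scatter) from compound 3 to compound 4, 1.9-fold (0.29 log units) apart, within the scatter of two such steps. Going by these compounds alone, this rests on only two pairs of compounds in one cell assay, so it does not show that the change would act alike on any further core, nor why the number falls.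

From the compounds shown here alone, whether other groups at this place would match hydroxy remains open. A primary amine, a methoxy group, a carboxylic acid or a longer chain carrying the hydroxy could each be compared on both cores.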